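Swapping the benzyl substituent toward an unmeasured fluorophenyl analogue

This account rests on a few compounds, and the source may have more. Where it says the series, first, only, none or still open, it means among the compounds named here.

Measured compounds:
Compound 1, `COc1ccc(CNC(=O)c2nc(-c3ccc(F)cc3)n(CC[C@@H](O)C[C@@H](O)CC(=O)O)c2C2CC2)cc1`, gives 6400 nM in a functional assay on L6 cells (Rattus norvegicus) for inhibition, read by scintillation counting, with a stated time of 3 h; a higher number here means a weaker inhibitor, a lower number a stronger inhibitor.
Compound 2, `Cc1ccc(CNC(=O)c2nn(-c3ccc(F)cc3)c(CC[C@@H](O)C[C@@H](O)CC(=O)O)c2C(C)C)cc1`, gives 730 nM in this assay.
Compound 3, `CN(C)S(=O)(=O)c1ccc(CNC(=O)c2nc(-c3ccc(F)cc3)n(CC[C@@H](O)C[C@@H](O)CC(=O)O)c2C2CC2)cc1`, gives only a limit, > 100000 nM, in this assay.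

The value for compound 3 is a limit of the assay rather than a number, so compound 3 is known only to sit at the weak end of what was measured here; this is the case described by the limit of > 100000 nM in this assay, at which 1 of the 3 values shown sits. Within the data shown here, the one step that connects two measured compounds differing in a single place is an at least 15-fold higher number from compound 1 to compound 3 (1.19 log units; beyond the scatter), a large loss of inhibition when the dimethylsulfamoyl group replaces methoxy.

Compound 4, `O=C(O)C[C@H](O)C[C@H](O)CCn1c(-c2ccc(F)cc2)nc(C(=O)NCc2cccc(F)c2)c1C1CC1`, has not yet been measured. It differs from compound 3 as follows: 3-fluorophenyl in place of 4-(dimethylsulfamoyl)phenyl on a saturated chain carbon bound to an amide-type nitrogen. This change removes the very group whose entry drove the large step from compound 1 to compound 3, so a return toward the region of compound 1 is expected, with an at least 20-fold lower number from compound 3 to compound 4 (1.30 log units; beyond the scatter). Compound 4 is therefore estimated to give 5000 nM, with a likely range from 1500 nM to 30000 nM.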

Compound 4, half-maximal inhibitory concentration: 444 nM
The estimate for compound 4 lay 11-fold (1.05 log units) above the measured number, outside the stated range (below it).
By their numbers in this assay, from the lowest: compounds 4 and 2 (each within the scatter of the next); then compound 1. At a limit, above all of these: compound 3.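

Among these compounds, until now, the only change seen on this aromatic ring was one that lost inhibition; compound 4 shows that a different group at this place, on a saturated chain carbon bound to an amide-type nitrogen, can gain it. In this assay, 3-fluorophenyl in place of 4-methoxyphenyl gives a 14-fold lower number from compound 1 to compound 4 (1.16 log units; beyond the scatter), and 3-fluorophenyl in place of 4-(dimethylsulfamoyl)phenyl gives an at least 220-fold lower number from compound 3 to compound 4 (2.35 log units; beyond the scatter). The second step starts from a limit for compound 3 and not from a number: the limit of > 100000 nM in this assay, at which 1 of the 4 values shown sits.

The compounds shown cannot tell whether the gain comes from the fluorine itself or from losing the 4-methoxy group, and an unsubstituted phenyl ring at this place would separate the two. On these data alone, how a chlorine atom, a nitrile or an amine on this ring would compare also remains open.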